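A few compounds are considered here, and "the series" means these few. Any claim that something is new, unique, unknown or untested is made for them only; others in the source may bear on it.

Compound 1 `NS(=O)(=O)c1cccc(-c2cccc(OC(=O)NC3CCCCC3)c2)c1` in an assay on cell membranes for binding affinity to Fatty-acid amide hydrolase 1 (Rattus norvegicus) (a lower number here means a stronger inhibitor, a higher number a weaker inhibitor), gives 26.5 nM. Compound 2 `N#Cc1cccc(-c2cccc(OC(=O)NC3CCCCC3)c2)c1` in this assay gives 33.9 nM. The step of a 1.3-fold higher number from compound 1 to compound 2 (0.11 log units; within the scatter) exchanges one small group for another on the same aromatic carbon. Among the compounds with values here, compound 2 therefore stands within the scatter of compound 1, the only other number so far, and neither can be set apart from the other on these data.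

Compound 3 `O=C(NC1CCCCC1)Oc1cccc(-c2cccc(CCO)c2)c1` differs from compound 2 only by 2-hydroxyethyl in place of cyano on an aromatic carbon. Within the data shown here, the single measured step that touches this position, a 1.3-fold higher number from compound 1 to compound 2 (0.11 log units; within the scatter), was small, so the identity of the group on that carbon has so far made little difference. Among the measured compounds shown here, for compound 3 a step of a 1.2-fold higher number from compound 2 to compound 3 (0.07 log units; within the scatter) is expected, that is none beyond the scatter, with a wide range since no hydroxyethyl group has yet been measured. Compound 3 is expected to give 40 nM in this assay, with a range of 14 nM to 120 nM.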

Compound 3, half-maximal inhibitory concentration: 18.7 nM
Beside the measured number, compound 3's estimate is 2.1-fold (0.33 log units) above it, and the stated range covers the measured number.
By their numbers in this assay, from the lowest: compounds 3, 1 and 2 (each within the scatter of the next).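

The series now holds three groups on this aromatic carbon, and in this assay the step of a 1.8-fold lower number from compound 2 to compound 3 (0.26 log units; within the scatter) stays inside the scatter, as does the step of a 1.4-fold lower number from compound 1 to compound 3 (0.15 log units; within the scatter) on the same carbon. Within the data shown here, the earlier pair showed this only for sulfamoyl and cyano, whereas 2-hydroxyethyl brings a short chain without a triple bond and, unlike cyano, one hydrogen-bond donor, and still no step leaves the scatter, so on these three compounds the number does not separate the groups. No data at hand bear on why these groups read alike.

As far as these compounds go, whether an amine, a carboxylic acid or a longer chain on this carbon would give a step beyond the scatter remains open. So does whether the three groups shown would also read alike on another carbon of that ring, or with another group in place of the cyclohexyl on the carbamate nitrogen.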